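From Hydroxy to Methylamino on a Side Chain

This account rests on a few compounds, and the source may have more. Where it says the series, first, only, none or still open, it means among the compounds named here.

Going by the values given here, compound 2 (`C=C(c1ccc(OC)cc1NC(=O)CO)c1ccc(OC)c2c1OC(C)(C)C=C2`) gives 100 nM in a functional assay on MCF7 cells (Homo sapiens) for antiproliferative activity, read by MTT assay, with a stated time of 48 h (on this read-out higher numbers stand for weaker inhibition and lower numbers for stronger inhibition), and holds the lowest number of the three compounds measured so far, which makes it the strongest inhibitor among them. Compound 1 (`COc1ccc(C(=O)c2ccc(OC)c3c2OC(C)(C)C=C3)c(NC(=O)CN)c1`) gives 410 nM in this assay and compound 3 (`COc1ccc(C(=O)c2cc(OC)c(OC)c(OC)c2)c(NC(=O)CN(C)C)c1`) gives 790 nM there, and both numbers lie clearly above that of compound 2.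

The next compound to test is compound 4 (`C=C(c1ccc(OC)cc1NC(=O)CNC)c1ccc(OC)c2c1OC(C)(C)C=C2`). It matches compound 2 except for one change, methylamino in place of hydroxy on a saturated chain carbon bound to a carbonyl carbon.

Among the compounds with values here, no measured pair shows this change on its own, so the evidence is indirect. Compound 1 and compound 3 both carry a nitrogen group on the corresponding side chain and both have higher numbers than compound 2, which hints at weaker inhibition. That hint is weak, since both also differ from compound 2 elsewhere in the structure. A small rise is therefore expected, perhaps no larger than the usual scatter, and the estimated step is a 1.6-fold higher number from compound 2 to compound 4 (0.20 log units; within the scatter) as a rough guide.

Compound 4 is expected to give 160 nM in this assay (estimated range 50 nM to 500 nM).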

Compound 4, half-maximal inhibitory concentration: 400 nM
The estimate for compound 4 lay 2.5-fold (0.40 log units) below the measured number; the measured number falls inside the stated range.
By their numbers in this assay, from the lowest: compound 2; then compounds 4, 1 and 3 (each within the scatter of the next).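

Going by these compounds alone, this pair gives the first direct reading of this change, since compound 2 and compound 4 differ in one place only. In this assay, methylamino in place of hydroxy on a saturated chain carbon bound to a carbonyl carbon gives a 4.0-fold higher number from compound 2 to compound 4 (0.60 log units; beyond the scatter), a modest step, yet one that lies beyond the scatter, so this position responds to a swap even when the two groups have the same count of hydrogen-bond donors and acceptors and neither carries a net charge. Nothing available here accounts for the rise in the number.

The pair cannot separate the exchange of oxygen for nitrogen from the added methyl carbon, and it does not show how an ethylamino group, a longer chain ending in an amine, or a carboxylic acid at this place would read on the core of compound 2. On these data alone, whether the same change gives a step of similar size on the core of compound 1 or compound 3 also stays open, as neither of those compounds has a partner that differs from it in this one place.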